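Swapping methoxy for hydroxy in compound 1

A few compounds are considered here, and "the series" means these few. Any claim that something is new, unique, unknown or untested is made for them only; others in the source may bear on it.

Compound 1 `COc1cc(/C=C/C(=O)OCCCO[N+](=O)[O-])ccc1OCCCO[N+](=O)[O-]` offers no exact starting point in a functional assay on cells (Homo sapiens) for cytotoxicity, read by resazurin assay, with a stated time of 72 h; a lower number here means a stronger inhibitor, a higher number a weaker inhibitor. Compound 1 gives > 50000 nM, which is a limit and not a number. Compound 2 `COc1cc(/C=C/C(=O)OCCCO[N+](=O)[O-])ccc1O`, with hydrogen in place of 3-(nitrooxy)propyl on an oxygen on an aromatic ring, gives 39400 nM. Compound 3 `O=C(/C=C/c1ccc(OCCCO[N+](=O)[O-])c(O)c1)OCCCO[N+](=O)[O-]` instead departs from compound 1 by hydrogen in place of methyl on an oxygen on an aromatic ring, methoxy to hydroxy. Among the measured compounds shown here, the one measured step that bears on this change is an at least 1.2-fold lower number from compound 1 to compound 2 (0.10 log units; that floor lies within the scatter). That step also puts hydrogen on an oxygen on an aromatic ring, but it replaces a different group. On that evidence, only a small move toward a lower number is expected, with none clearly beyond the scatter. The expected change is an at least 1.6-fold lower number from compound 1 to compound 3 (0.22 log units; that floor lies within the scatter). The estimated value for compound 3 is 30000 nM, with an expected range of 10000 nM to 60000 nM.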

Compound 3, half-maximal inhibitory concentration: 4980 nM
Beside the measured number, compound 3's estimate is 6.0-fold (0.78 log units) above it; the whole stated range lies above it.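

In this assay, hydrogen in place of methyl on an oxygen on an aromatic ring gives an at least 10-fold lower number from compound 1 to compound 3 (1.00 log units; beyond the scatter), a change that clearly lies beyond the scatter. The earlier step, an at least 1.2-fold lower number from compound 1 to compound 2 (0.10 log units; that floor lies within the scatter), put hydrogen on such an oxygen in place of 3-(nitrooxy)propyl and showed no such clear change, so the outcome here depends on which group leaves and where it sits on the core of compound 1. The printed step is only a floor, and its true size cannot be read from the data: the limit of > 50000 nM in this assay, at which 1 of the 3 values shown sits.

The compounds shown leave open whether the lower number belongs to the hydroxy group itself or simply to the loss of the methyl. An amine or an ethoxy group at this oxygen-bearing place would help separate those two readings.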